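The compounds below may be only part of what the source reports. "The series", "measured", "known", "first", "only" and "open" are said of these compounds alone.

Measured so far:
compound 1, `COc1ccc(-c2cn3ccnc3c(-c3ccc4ncn(C5CCCCC5)c4c3)n2)cc1`, 97.4%
compound 2, `c1cn2cc(-c3ccsc3)nc(-c3ccc4ncn(C5CCCCC5)c4c3)c2n1`, 21.8%

In a functional assay on MDA-MB-468 cells (Homo sapiens) for inhibition, read by sulforhodamine B assay, with a stated time of 48 h, tested at 10 uM (on this read-out lower numbers stand for less inhibition and higher numbers for more inhibition at the one concentration tested (going by the name of the read-out)), compound 1 gives 97.4%, whereas compound 2 gives the lower of the two values, 21.8%. Within the data shown here, the only step on record, a number 75.6 percentage points lower from compound 1 to compound 2 (beyond the scatter), shows how much this read-out can move when the group on that aromatic carbon changes. Compound 3, `Fc1ccccc1-c1cn2ccnc2c(-c2ccc3ncn(C4CCCCC4)c3c2)n1`, is not yet measured. It differs from compound 2 as follows: 2-fluorophenyl in place of thiophen-3-yl on an aromatic carbon. The entering group is again a six-membered aromatic ring, as in compound 1, so the expected step is a number 48.2 percentage points higher from compound 2 to compound 3 (beyond the scatter), a rise back toward compound 1 though with wide uncertainty. Compound 3 is estimated at 70%, within 35% to 95%.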

Compound 3, a percentage reported as inhibition, at one concentration (the size of the read-out at that concentration, not a potency): 27.6%
Beside the measured number, compound 3's estimate is 42.4 percentage points above it, outside the stated range (below it).
By their numbers in this assay, from the lowest: compounds 2 and 3 (each within the scatter of the next); then compound 1.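

The step of a number 5.8 percentage points higher from compound 2 to compound 3 (within the scatter) means that 2-fluorophenyl and thiophen-3-yl cannot be told apart at this position. A six-membered aromatic ring here is therefore not enough for a high value, as the change from 4-methoxyphenyl to 2-fluorophenyl gives a number 69.8 percentage points lower from compound 1 to compound 3 (beyond the scatter) and so the ring's substituent matters. No measured evidence accounts for this difference.

On these data alone, what stays open is whether the methoxy group itself or its place on the ring matters, since 4-methoxyphenyl and 2-fluorophenyl differ in both. A 2-methoxyphenyl or 4-fluorophenyl group would help separate the two.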